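A few compounds are considered here, and "the series" means these few. Any claim that something is new, unique, unknown or untested is made for them only; others in the source may bear on it.

Measured so far in a functional assay on MDA-N cells (Homo sapiens) for antiproliferative activity; on this read-out higher numbers stand for weaker inhibition of growth and lower numbers for stronger inhibition of growth:
compound 1 `Cc1cc(C)c2c(O)cc(-c3cccc(F)c3)nc2n1`: 12.9 nM
compound 2 `Cc1ccnc2nc(-c3ccc4ccccc4c3)cc(O)c12`: 204 nM

Not yet measured:
compound 3 `Cc1cccc(-c2cc(O)c3c(C)cc(C)nc3n2)c1`

Compound 1 stands lowest of the two numbers in this assay, and the gap up to compound 2 lies beyond the usual scatter. Among the compounds with values here, these two compounds differ in more than one place, so the data hold no single-change step to serve as a guide.

Compound 3 keeps the core of compound 1 and carries methyl in place of fluoro on an aromatic carbon. Within the data shown here, no measured pair isolates this exchange, so any expectation is weakly founded. Among the measured compounds shown here, with compound 1 at 12.9 nM, the lower of only two values, a move towards a higher number in this assay is expected to be the likelier direction, with a size near the edge of the scatter. The estimated change is a 1.9-fold higher number from compound 1 to compound 3 (0.29 log units; within the scatter). For compound 3 the estimated value is 25 nM, with an expected range from 8 nM to 80 nM.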

Compound 3, concentration for 50% growth inhibition: 20900 nM
Estimate against measurement, compound 3: 840-fold (2.92 log units) below, outside the stated range (above it).
By their numbers in this assay, from the lowest: compound 1; then compound 2; then compound 3.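

In this assay the aromatic carbon meta to a large group, on the six-membered aromatic ring of carbon only, turns out to be highly sensitive to what it carries: methyl in place of fluoro gives a 1600-fold higher number from compound 1 to compound 3 (3.21 log units; beyond the scatter) and so moves the series from strong to weak inhibition of growth. The exchange is small by count, one heavy atom for one heavy atom, with no ring, hydrogen-bond donor, hydrogen-bond acceptor or net charge entering or leaving, yet the step lies far beyond the scatter and the core of compound 1 stays unchanged. Nothing at hand bears on why so small an exchange has so large an effect on this read-out.

Only fluoro and methyl are shown at this place, so it stays open whether the sharp rise in the number is specific to methyl or would also follow a chlorine atom, a methoxy group or an amine there. Also open, as far as these compounds go, is where a plain hydrogen at this carbon would fall relative to compound 1 and compound 3, which would show whether fluoro raises activity, methyl removes it, or both.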